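A few compounds are considered here, and "the series" means these few. Any claim that something is new, unique, unknown or untested is made for them only; others in the source may bear on it.

Measured compounds:
Compound 1, `C/C(=N/Nc1nc(-c2ccc(C#N)cc2)cs1)c1cccnc1`: 40%
Compound 2, `C/C(=N/Nc1nc(-c2ccc([N+](=O)[O-])cc2)cs1)c1cccnc1`: "not active" (no number reported)
Compound 3, `C/C(=N/Nc1nc(-c2ccc(F)cc2)cs1)c1cccs1`: 40%
Compound 4, `C/C(=N/Nc1nc(-c2ccc(F)cc2)cs1)c1cccnc1`: not yet measured

The measurement here is an in vitro assay on BTI-TN-5B1-4 cells for inhibition of Amine oxidase [flavin-containing] A (Homo sapiens), read by Amplex Red, with a stated time of 15 min, tested at 100 uM; a higher number here means more inhibition at the concentration tested (going by the name of the read-out), a lower number less inhibition. In this assay compound 1 gives 40%, compound 2 gives "not active" (no number reported), reported without a number, and compound 3 gives 40%. Compound 3 thus stands level with compound 1 at the digits shown, and the two values lie within the usual scatter of each other, so no order between them can be read. Among the compounds with values here, compound 2 stands apart as the one entry without a number.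

Compound 4 differs from compound 3 in one place: pyridin-3-yl in place of thiophen-2-yl on a carbon with a double bond to nitrogen. Within the data shown here, no measured pair shows this exact change, so its effect cannot be read from a step. What the shown values offer is that compound 1, which carries pyridin-3-yl, and compound 3, which carries thiophen-2-yl, give the same reading at the digits shown, although the two also differ elsewhere. On that basis, a step of no size beyond the scatter is expected in this assay, in neither direction. Compound 4 is expected to give 40%, with a range from 22% to 58%. This estimate means an expected step of no change at the digits printed from compound 3 to compound 4 (within the scatter), within the scatter.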

Compound 4, a percentage reported as inhibition, at one concentration (the size of the read-out at that concentration, not a potency): 40%
Beside the measured number, compound 4's estimate shows no gap at the digits printed, and the stated range covers the measured number.
By their numbers in this assay, from the lowest: compounds 1, 3 and 4 (each within the scatter of the next).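

In this assay, within the data shown here, the exchange of thiophen-2-yl for pyridin-3-yl on the carbon with a double bond to nitrogen gives no change at the digits printed from compound 3 to compound 4 (within the scatter) and so provides the first direct reading of this change: at this position, the two rings cannot be told apart in this measurement. Compound 4 also ties the set together, since fluoro in place of cyano on an aromatic carbon gives no change at the digits printed from compound 1 to compound 4 (within the scatter) with the rest of the molecule held constant, which shows that this aromatic position too can change without moving the reading. Among these compounds, that holds only for these two groups, as compound 2, with a nitro group on that carbon, is recorded as "not active" (no number reported) and offers no step that can be read.

Nothing measured here gives a reason for the unchanged readings. Still open, from the compounds shown here alone, is whether an amine or a carboxylic acid on the aromatic carbon, or a longer chain or a phenyl ring on the carbon with a double bond to nitrogen, would leave the reading where it stands.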